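The source may report more compounds than this note shows. Statements on the series, on what has been measured and on what is new or still open speak of the compounds shown alone.

Measured compounds:
Compound 1, `CCN(CC)c1ccc2cc(C(=O)c3ccc(N4CCN(C(=O)CN5CCN(S(=O)(=O)c6ccc(OC(F)(F)F)cc6)CC5)CC4)cc3)oc2c1`: 34700 nM
Compound 2, `CCN(CC)c1ccc2cc(C(=O)c3ccc(N4CCN(C(=O)CN5CCN(S(=O)(=O)c6ccc(C#N)cc6)CC5)CC4)cc3)oc2c1`: 44100 nM

Both numbers come from an ADME assay on L02 cells (Homo sapiens) for cytotoxicity, read by MTT assay, with a stated time of 48 h; a higher number here means a weaker inhibitor, a lower number a stronger inhibitor. Among the measured compounds shown here, on these two values compound 2 carries the higher number, but its only neighbour is compound 1, and that gap is small: a 1.3-fold higher number from compound 1 to compound 2 (0.10 log units; within the scatter). So the two measured compounds sit within the scatter of each other, and no order between them can be claimed.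

Compound 3, `CCOC(=O)CN1CCN(CC(=O)N2CCN(c3ccc(C(=O)c4cc5ccc(N(CC)CC)cc5o4)cc3)CC2)CC1`, has not yet been measured in this assay. Its change from compound 2 is (ethoxycarbonyl)methyl in place of (4-cyanophenyl)sulfonyl on an amine nitrogen in a ring. For the measured compounds named here, the single measured step, a 1.3-fold higher number from compound 1 to compound 2 (0.10 log units; within the scatter), concerns a substituent on the aromatic ring of the group that leaves here; it does not test an exchange of the whole group on the amine nitrogen in a ring, so it offers no direct guide to this change. Going by the values given here, with no step in the data pointing in either direction, the expectation is a change no larger than the scatter: the step from compound 2 to compound 3 is estimated as a 1.1-fold lower number from compound 2 to compound 3 (0.04 log units; within the scatter). Compound 3 is therefore expected to give about 40000 nM in this assay, with an estimated range from 15000 nM to 110000 nM.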

Compound 3, half-maximal inhibitory concentration: 68700 nM
For compound 3 the middle estimate is 1.7-fold (0.23 log units) below the measured one, within the range that was stated.
By their numbers in this assay, from the lowest: compounds 1, 2 and 3 (each within the scatter of the next).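

Exchanging the whole group on the amine nitrogen in a ring, with (ethoxycarbonyl)methyl in place of (4-cyanophenyl)sulfonyl, gives a 1.6-fold higher number from compound 2 to compound 3 (0.19 log units; within the scatter) in this assay. The earlier pair differed only in a substituent on the aromatic ring of the sulfonyl group, whereas this step removes both that ring and the sulfonyl group, and the result still stays within the scatter. For this one exchange, then, the number in this cell assay does not depend measurably on keeping a sulfonyl-linked aromatic ring at this nitrogen, and no measurement shown here gives a reason for that result.

Because the sulfonyl group and the aromatic ring leave together, the compounds shown cannot separate what each contributes, and a simple methylsulfonyl group on the same nitrogen would begin to pull the two apart. Going by these compounds, it also remains open whether a free carboxylic acid in place of the ethyl ester, a longer chain between the nitrogen and the ester, or a terminal amine would stay equally close to these compounds.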